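The source may hold more compounds than are shown below. What is called first, only, known or untested is meant among the compounds shown, and "the series" means these compounds.

For the measured compounds named here, compound 3 `O=C(CCC(=O)OCCCCCCSc1ccc([N+](=O)[O-])c2nonc12)Nc1cccc(Cl)c1` gives 1100 nM in an assay on isolated protein for inhibition of glutathione S-transferase Mu 2 (Homo sapiens), with a stated time of 10 min (on this read-out lower numbers stand for stronger inhibition and higher numbers for weaker inhibition), the highest of the three numbers measured so far. Compound 1 `O=C(O)CCC(=O)OCCCCCCSc1ccc([N+](=O)[O-])c2nonc12` gives 160 nM, and compound 2 `O=C(CCC(=O)OCCCCCCSc1ccc([N+](=O)[O-])c2nonc12)Nc1ccccc1F` gives 350 nM; the steps of a 6.9-fold higher number from compound 1 to compound 3 (0.84 log units; beyond the scatter) and a 2.2-fold higher number from compound 1 to compound 2 (0.34 log units; beyond the scatter) both lie beyond the scatter. Compound 4 `Cc1ccc(NC(=O)CCC(=O)OCCCCCCSc2ccc([N+](=O)[O-])c3nonc23)cc1` differs from compound 3 in one place: 4-methylphenyl in place of 3-chlorophenyl on an amide-type nitrogen. Going by the values given here, the only measured step that swaps the ring on the amide nitrogen is a 3.1-fold higher number from compound 2 to compound 3 (0.50 log units; beyond the scatter), a modest shift, so a change of that order is what the data support. A modest step toward a lower number is therefore expected for a 1.7-fold lower number from compound 3 to compound 4 (0.23 log units; within the scatter), though it may not clear the scatter. Compound 4 is estimated at 650 nM, within 250 nM to 1800 nM.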

Compound 4, half-maximal inhibitory concentration: 390 nM
Compound 4: middle estimate off by 1.7-fold (0.22 log units), on the high side; low and high end bracket the measured number.
By their numbers in this assay, from the lowest: compound 1; then compounds 2 and 4 (each within the scatter of the next); then compound 3.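

Putting 4-methylphenyl in place of 3-chlorophenyl on the amide-type nitrogen gives a real change, a 2.8-fold lower number from compound 3 to compound 4 (0.45 log units; beyond the scatter), while replacing 2-fluorophenyl with it gives a 1.1-fold higher number from compound 2 to compound 4 (0.05 log units; within the scatter), so these two rings cannot be told apart here. Replacing hydroxy on the carbonyl carbon with (4-methylphenyl)amino still gives a 2.4-fold higher number from compound 1 to compound 4 (0.39 log units; beyond the scatter), the same direction as with the other two amides. Nothing available explains these differences. Open, going by these compounds, is how a plain phenyl or 4-methoxyphenyl on that nitrogen would compare, and whether the same ring group placed elsewhere on the ring would give the same number.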